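The source may hold more compounds than are shown below. What is called first, only, known or untested is meant among the compounds shown, and "the series" means these compounds.

Measured in an in vitro ADME assay on microsomes from liver (Mus musculus) for pharmacokinetics, read by LC-MS; a higher number here means faster removal of the compound, a lower number slower removal:

Compound 1 `Cc1ccc2c(c1)nc(C)n2-c1ccc(C(=O)NC2CC2)s1`: > 72 mL/min/kg (a limit)
Compound 2 `Cc1nc2cc(OC(F)(F)F)ccc2n1-c1ccc(C(=O)NC2CC2)s1`: 43 mL/min/kg
Compound 3 `COc1cccc2c1nc(C)n2-c1ccc(C(=O)NC2CC2)s1`: > 72 mL/min/kg (a limit)

Compound 3 stands at > 72 mL/min/kg, which is a limit and not a number. Among the compounds with values here, the series so far is marked by the limit of > 72 mL/min/kg in this assay, at which 2 of the 3 values shown sit, so compound 2 alone gives a true number, 43 mL/min/kg.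

Compound 4 `Cc1nc2c(Br)cccc2n1-c1ccc(C(=O)NC2CC2)s1` carries bromo in place of methoxy on an aromatic carbon, ortho to a fused ring and meta to a fused ring (bromo in place of methoxy on an aromatic carbon). Within the data shown here, no measured step makes this same swap. The nearest guide is a different swap on the shared core, an at least 1.6-fold lower number from compound 1 to compound 2 (0.22 log units; that floor lies within the scatter). That single step is weak guidance for compound 4, and it points only to a modest move towards slower removal. Compound 4 may also stay at the limit of this assay.

The expected change is small and downward, an estimated at least 1.2-fold lower number from compound 3 to compound 4 (0.07 log units; that floor lies within the scatter). The estimated clearance of compound 4 is 60 mL/min/kg, with an expected range from 32 mL/min/kg to 110 mL/min/kg.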

Compound 4, clearance: 26 mL/min/kg
Beside the measured number, compound 4's estimate is 2.3-fold (0.36 log units) above it, and the stated range ends above it.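

In this assay, putting bromo in place of methoxy on an aromatic carbon, ortho to a fused ring and meta to a fused ring, gives an at least 2.7-fold lower number from compound 3 to compound 4 (0.44 log units; beyond the scatter). Compound 3 stands at > 72 mL/min/kg, which is a limit. The earlier compounds gave no true number at this place on the shared core, so this step is the first to show that a change here can bring the read-out clearly down, and its size is only a floor because the starting compound sits at the edge of what the assay reports: the limit of > 72 mL/min/kg in this assay, at which 2 of the 4 values shown sit.

The compounds shown leave open whether the lower number belongs to bromo in particular or would follow from other replacements of methoxy at this place, such as chloro, a nitrile or a hydroxyl group. They also leave open whether bromo would give a similar result at other aromatic carbons of the same six-membered ring, where the methyl of compound 1 and the trifluoromethoxy of compound 2 are found.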